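Methoxy added to the 2-methoxyphenyl group of compound 3

The source may report more compounds than this note shows. Statements on the series, on what has been measured and on what is new or still open speak of the compounds shown alone.

In a functional assay on K562 cells (Homo sapiens) for antiproliferative activity, read by MTT assay, with a stated time of 72 h (on this read-out higher numbers stand for weaker inhibition and lower numbers for stronger inhibition), compound 1 `COc1cc(C(=O)c2sc3ccccc3c2-c2ccc(Cl)cc2)cc(OC)c1OC` gives 4200 nM, compound 2 `COc1cc(C(=O)c2sc3ccccc3c2-c2ccc(C)cc2)cc(OC)c1OC` gives 3500 nM and compound 3 `COc1ccccc1-c1c(C(=O)c2cc(OC)c(OC)c(OC)c2)sc2ccccc12` gives 3400 nM. These values all lie within the scatter of one another, so compound 3 holds no distinct place among them. Compound 4 `COc1ccc(OC)c(-c2c(C(=O)c3cc(OC)c(OC)c(OC)c3)sc3ccccc23)c1` differs from compound 3 by one change: methoxy in place of hydrogen on an aromatic carbon, methoxy in place of hydrogen, turning 2-methoxyphenyl into 2,5-dimethoxyphenyl. The nearest evidence is a 1.2-fold lower number from compound 1 to compound 3 (0.09 log units; within the scatter) and a 1.0-fold lower number from compound 2 to compound 3 (0.01 log units; within the scatter), together with a 1.2-fold lower number from compound 1 to compound 2 (0.08 log units; within the scatter), all within the scatter. None of these adds a group to the 2-methoxyphenyl ring, so the support is indirect. The expected step is a 1.1-fold lower number from compound 3 to compound 4 (0.05 log units; within the scatter), with none beyond the scatter in this assay. Compound 4 is estimated at 3000 nM, within a range of 1200 nM to 7000 nM.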

Compound 4, half-maximal inhibitory concentration: > 10000 nM
Compound 4: only a limit was reported; the forecaster's own chance of this, stated with the estimate: 8%; middle value at least 3.3-fold (0.52 log units) away from the limit.
By their numbers in this assay, from the lowest: compounds 3, 2 and 1 (each within the scatter of the next). At a limit, above all of these: compound 4.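

In this assay, methoxy entering para to the methoxy group of compound 3, turning 2-methoxyphenyl into 2,5-dimethoxyphenyl, is the only change shown on this ring that goes beyond the scatter: an at least 2.9-fold higher number from compound 3 to compound 4 (0.46 log units; beyond the scatter). The swaps from 4-methylphenyl and 4-chlorophenyl read the same way, an at least 2.8-fold higher number from compound 2 to compound 4 (0.45 log units; beyond the scatter) and an at least 2.3-fold higher number from compound 1 to compound 4 (0.37 log units; beyond the scatter), whereas steps among the three earlier groups stayed within the scatter. Compound 4 stands at a limit, not a number, so the full size of these steps stays unknown: the limit of > 10000 nM in this assay, at which 1 of the 4 values shown sits.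

On these data alone, whether the loss belongs to this place or to any second group on the ring stays open. As far as these compounds go, how a fluoro, hydroxyl or amine at the same place would read also stays open.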